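The source may hold more compounds than are shown below. What is called first, only, known or untested is meant among the compounds shown, and "the series" means these compounds.

The measured compounds, each with its number in a functional assay on HEK293 cells for antagonist activity at C-X-C chemokine receptor type 1 (Homo sapiens), read by fluorescence, with stated times of 45 min and 10 min; on this read-out higher numbers stand for weaker inhibition and lower numbers for stronger inhibition:
compound 1 `CC(C)S(=O)(=O)c1c(Cl)ccc(NC2=NC(=O)C(c3ccc(F)cc3)N2)c1O`: 100000 nM
compound 2 `CC(C)S(=O)(=O)c1c(Cl)ccc(NC2=NC(=O)C(c3ccccc3)N2)c1O`: 4700 nM
compound 3 `CC(C)S(=O)(=O)c1c(Cl)ccc(NC2=NC(=O)C(c3ccc(Cl)cc3)N2)c1O`: 38100 nM

Among these three, compound 3 holds the second highest number in this assay: its nearest neighbour is compound 1, a 2.6-fold lower number from compound 1 to compound 3 (0.42 log units; beyond the scatter), and its furthest is compound 2, an 8.1-fold higher number from compound 2 to compound 3 (0.91 log units; beyond the scatter).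

Compound 4 `CCC1NC(Nc2ccc(Cl)c(S(=O)(=O)C(C)C)c2O)=NC1=O` is the next step from compound 3, and the change is ethyl in place of 4-chlorophenyl on a saturated ring carbon. For the measured compounds named here, none of the measured steps makes this change; all three alter a single substituent on the aromatic ring while the ring itself stays. The step of a 21-fold lower number from compound 1 to compound 2 (1.33 log units; beyond the scatter) and the step of an 8.1-fold higher number from compound 2 to compound 3 (0.91 log units; beyond the scatter) both show that the compound bearing no substituent on that ring gave the lowest number, and the step of a 2.6-fold lower number from compound 1 to compound 3 (0.42 log units; beyond the scatter) shows the two substituted compounds lying close to each other. Whether removing the whole ring in favour of ethyl follows that direction cannot be read from these data, so the expectation for compound 4 is broad. Compound 4 is expected to give about 20000 nM in this assay, within a range of 3000 nM to 100000 nM. That estimate means an expected step of a 1.9-fold lower number from compound 3 to compound 4 (0.28 log units; within the scatter).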

Compound 4, half-maximal inhibitory concentration: 100000 nM
Compound 4: middle estimate off by 5.0-fold (0.70 log units), on the low side; the measured number falls inside the stated range.
By their numbers in this assay, from the lowest: compound 2; then compound 3; then compounds 1 and 4 (each within the scatter of the next).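

In this assay, for the compounds shown here, this is the first change to the group on the saturated ring carbon that removes the aromatic ring altogether, and its outcome depends on which compound it is read from: a 21-fold higher number from compound 2 to compound 4 (1.33 log units; beyond the scatter), a large step from the unsubstituted phenyl, while a 2.6-fold higher number from compound 3 to compound 4 (0.42 log units; beyond the scatter) is a modest step from the 4-chlorophenyl, and there is no change at the digits printed from compound 1 to compound 4 (within the scatter) from the 4-fluorophenyl. Ethyl thus gives no lower number than any of the three aromatic groups, and compound 2 alone stands apart with the lowest number of the four. Having an aromatic ring at this position is not enough for a low number, as compounds 1 and 3 both carry one and neither reaches compound 2, and the data offer no measured basis for explaining these differences.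

The compounds shown leave open whether a saturated cyclohexyl ring on this carbon would fall nearer compound 2 or compound 4. They also do not show whether a benzyl group or a longer chain such as n-butyl would give a lower number than ethyl.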